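Replacing the Carboxyphenyl Group on the Sulfonyl of Compound 1

This account rests on a few compounds, and the source may have more. Where it says the series, first, only, none or still open, it means among the compounds named here.

Measured compounds:
compound 1, `Cn1c(=O)c(S(=O)(=O)c2ccc(C(=O)O)cc2)cc2cnc(Nc3ccc4[nH]ccc4c3)nc21`, 10000 nM
compound 2, `Cn1c(=O)c(S(=O)(=O)c2ccccc2)cc2cnc(Nc3cnc4[nH]ccc4c3)nc21`, 1000 nM
compound 3, `COc1ccc(Nc2ncc3cc(S(=O)(=O)c4ccc(Cl)cc4)c(=O)n(C)c3n2)cc1`, 30000 nM

In a functional assay on DU-145 cells (Homo sapiens) for inhibition, read by trypan blue exclusion, with a stated time of 72 h (a higher number here means a weaker inhibitor, a lower number a stronger inhibitor), compound 1 gives 10000 nM, the second highest of the three numbers; compound 3 gives a higher number and compound 2 a lower one, both gaps beyond the scatter. Compounds 2 and 3 differ from compound 1 in more than one place, so no single step can be read from them.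

Compound 4, `Cn1c(=O)c(S(=O)(=O)c2ccc(F)cc2N)cc2cnc(Nc3ccc4[nH]ccc4c3)nc21`, differs from compound 1 in one place: 2-amino-4-fluorophenyl in place of 4-carboxyphenyl on a sulfonyl sulfur. Among the compounds with values here, no measured step shows what this change does, so the expectation rests on the spread of the three numbers and is uncertain. Compound 4 is expected to give 3000 nM, within 800 nM to 12000 nM, an expected step from compound 1 of a 3.3-fold lower number from compound 1 to compound 4 (0.52 log units; beyond the scatter), a moderate gain beyond the scatter.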

Compound 4, half-maximal inhibitory concentration: 3000 nM
Compound 4: the middle estimate sits on the measured number at the digits printed; low and high end bracket the measured number.
By their numbers in this assay, from the lowest: compound 2; then compound 4; then compound 1; then compound 3.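

In this assay, within the data shown here, the change on the sulfonyl sulfur gives a 3.3-fold lower number from compound 1 to compound 4 (0.52 log units; beyond the scatter), the first step that can be read at this place. It shows that the 4-carboxyphenyl group is not required for the activity of compound 1, and that 2-amino-4-fluorophenyl can take its place with a modest gain. Nothing measured here explains that gain.

The step swaps several features at once, so it cannot separate the effect of losing the carboxylic acid from that of adding the amine or the fluorine. Going by these compounds, how a 4-hydroxyphenyl group would behave at this place remains open.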